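Two amides at the assay ceiling and a trimmed anilide

The source may report more compounds than this note shows. Statements on the series, on what has been measured and on what is new or still open speak of the compounds shown alone.

Compound 1 `COc1ccc(NC(=O)c2cccc(/C=C3\CC(=O)N(c4ccccc4)C3=O)c2)c(C)c1` carries a 4-methoxy-2-methylphenyl anilide on the shared core. In an ADME assay on NCM460 cells (Homo sapiens) for cytotoxicity, read by MTT assay, with a stated time of 72 h (on this read-out higher numbers stand for weaker inhibition and lower numbers for stronger inhibition), compound 1 gives > 100000 nM, which is a limit of the assay rather than a number. Compound 2 `CCCCCN1C(=O)C/C(=C\c2cccc(C(=O)Nc3cccc(CC)c3)c2)C1=O` shares the arylidene imide framework with a pentyl group on the ring nitrogen and an ethylphenyl anilide. In this assay compound 2 likewise gives > 100000 nM, again a limit and not a measured figure. Both values therefore sit at the limit of > 100000 nM in this assay, at which 2 of the 2 values shown sit, so compound 1 stands nowhere above or below compound 2 on the numbers shown; neither shows measurable cytotoxicity on these cells within the tested range.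

Compound 3 `Cc1ccc(NC(=O)c2cccc(/C=C3\CC(=O)N(c4ccccc4)C3=O)c2)cc1` has not yet been measured in this assay. It differs from compound 1 by 4-methylphenyl in place of 4-methoxy-2-methylphenyl on an amide-type nitrogen. For the measured compounds named here, no step between measured compounds is available here. Because both shown values rest at the limit of > 100000 nM in this assay, at which 2 of the 2 values shown sit, the step from compound 1 to compound 3 is expected to be none beyond the scatter, with a number no higher from compound 1 to compound 3 (the limit leaves the size open) as the estimated change. Compound 3 is therefore expected to give about 100000 nM in this assay, within 30000 nM to 300000 nM.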

Compound 3, half-maximal inhibitory concentration: > 100000 nM
Compound 3 ended at the assay's limit; the forecaster's own chance of this, stated with the estimate: 80%; the middle value sits exactly at the limit.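

Compound 3 gives > 100000 nM in this assay, which is a limit of the assay. The step from compound 1 to compound 3 cannot be read, because both values are limits: the limit of > 100000 nM in this assay, at which 3 of the 3 values shown sit. The compounds shown leave open whether 4-methylphenyl in place of 4-methoxy-2-methylphenyl changes the result in this assay at all.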